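Swapping a Silyl Ether for a Formate on a Shared Core

The source may report more compounds than this note shows. Statements on the series, on what has been measured and on what is new or still open speak of the compounds shown alone.

Compound 1 `C=C1[C@@H](OC(C)=O)C[C@@H]2[C@](C)(CO[Si](C)(C)C(C)(C)C)[C@H](OC(C)=O)CC[C@@]2(C)[C@@H]1C[C@@H](Nc1ccccc1)C1=CCOC1=O` is the starting point. In a functional assay on MCF7 cells (Homo sapiens) for cytotoxicity, read by sulforhodamine B assay (on this read-out lower numbers stand for stronger inhibition and higher numbers for weaker inhibition), compound 1 gives 4840 nM. Two relatives change only the aromatic ring on the amine nitrogen: compound 2 `C=C1[C@@H](OC(C)=O)C[C@@H]2[C@](C)(CO[Si](C)(C)C(C)(C)C)[C@H](OC(C)=O)CC[C@@]2(C)[C@@H]1C[C@@H](Nc1ccccc1F)C1=CCOC1=O` gives 2930 nM and compound 3 `C=C1[C@@H](OC(C)=O)C[C@@H]2[C@](C)(CO[Si](C)(C)C(C)(C)C)[C@H](OC(C)=O)CC[C@@]2(C)[C@@H]1C[C@@H](Nc1cccc(F)c1)C1=CCOC1=O` gives 3820 nM. The three numbers cannot be told apart: the step of a 1.7-fold lower number from compound 1 to compound 2 (0.22 log units; within the scatter), the step of a 1.3-fold lower number from compound 1 to compound 3 (0.10 log units; within the scatter) and the step of a 1.3-fold higher number from compound 2 to compound 3 (0.12 log units; within the scatter) all stay inside the usual scatter, so compound 1 is neither stronger nor weaker than its two relatives on this evidence.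

Going by the values given here, compound 4 `C=C1[C@@H](OC(C)=O)C[C@@H]2[C@](C)(COC=O)[C@H](OC(C)=O)CC[C@@]2(C)[C@@H]1C[C@@H](Nc1ccccc1)C1=CCOC1=O` changes a different part of the molecule. a group of 2 heavy atoms (1 carbon, 1 oxygen; no ring) in place of a group of 7 heavy atoms (6 carbon, 1 silicon; no ring), on an oxygen on a saturated carbon None of the measured steps touches this position; all three concern fluoro on the aromatic ring, and all three were within the scatter. Among the compounds with values here, there is therefore no measured step that bears on the change from compound 1 to compound 4, and no direction can be read off from the data. The expectation for compound 4 is accordingly a number close to that of compound 1, with a wide range to reflect the lack of guidance. Compound 4 is estimated at 5000 nM, with a range from 1500 nM to 16000 nM. That estimate means an expected step of a 1.0-fold higher number from compound 1 to compound 4 (0.01 log units; within the scatter).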

Compound 4, half-maximal inhibitory concentration: 26200 nM
Compound 4: middle estimate off by 5.2-fold (0.72 log units), on the low side; the whole stated range lies below it.
By their numbers in this assay, from the lowest: compounds 2, 3 and 1 (each within the scatter of the next); then compound 4.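

The earlier compounds shown here changed only the aromatic ring on the amine nitrogen, and their numbers could not be told apart, so they gave no sign of what matters elsewhere on the shared core. Compound 4 shows that this other position does count in this assay: formyl in place of the group of 7 heavy atoms (6 carbon, 1 silicon), on an oxygen on a saturated carbon, gives a 5.4-fold higher number from compound 1 to compound 4 (0.73 log units; beyond the scatter), a step beyond the scatter and toward weaker inhibition. No measurement at hand offers a reason for this rise in the number.

With one replacement shown at this position, it remains open whether the rise reflects the loss of the silyl group or the presence of the formyl itself. A free hydroxyl, a methyl ether or a benzoyl ester on the same oxygen would help to separate those two readings, and a formyl version of the fluorinated compound 2 or compound 3 would test whether the same step holds with a fluoro on the aromatic ring.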